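Working notes: amide-nitrogen substituent, step to compound 4

This account rests on a few compounds, and the source may have more. Where it says the series, first, only, none or still open, it means among the compounds named here.

Measured so far:
- compound 1 `Cc1ccc(OCC(=O)N(Cc2cccs2)C2COC2)cc1`: 23000 nM
- compound 2 `Cc1ccc(OCC(=O)N(Cc2cccs2)c2nccn2C)cc1`: 1790 nM
- compound 3 `Cc1ccc(OCC(=O)N(Cc2cccs2)c2ccccc2)cc1`: 23 nM

All three numbers come from an assay on HEK293 cells for agonist activity at transient receptor potential cation channel subfamily M member 8 (Homo sapiens), read by fluorescence and calcium flux, with a stated time of 15 min; on this read-out higher numbers stand for an effect only at larger amounts of compound and lower numbers for an effect already at smaller amounts. Compound 3 gives the lowest number of the three; the nearest is compound 2, a 78-fold lower number from compound 2 to compound 3 (1.89 log units; beyond the scatter), and the furthest is compound 1, a 1000-fold lower number from compound 1 to compound 3 (3.00 log units; beyond the scatter). The remaining step among the measured compounds, a 13-fold lower number from compound 1 to compound 2 (1.11 log units; beyond the scatter), is also large, so the group on the amide-type nitrogen has moved the read-out over the whole range seen.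

Compound 4 `C=CCN(Cc1cccs1)C(=O)COc1ccc(C)cc1` has not yet been measured in this assay. It differs from compound 3 in one place: allyl in place of phenyl on an amide-type nitrogen. Going by the values given here, the steps that bear on this change are those in which the phenyl was exchanged for another group on the same nitrogen, namely from compound 1 to compound 3 and from compound 2 to compound 3, both large and both moving the number upward when the phenyl is absent. A large step is therefore expected in this assay, toward a higher number, for compound 4 as well: the expected step is a 220-fold higher number from compound 3 to compound 4 (2.34 log units; beyond the scatter). Compound 4 is estimated at 5000 nM, within a range from 800 nM to 30000 nM.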

Compound 4, half-maximal effective concentration: 20 nM
Compound 4: the middle estimate sits 250-fold (2.40 log units) above what was measured; the whole stated range lies above it.
By their numbers in this assay, from the lowest: compounds 4 and 3 (each within the scatter of the next); then compound 2; then compound 1.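

With the allyl on the amide-type nitrogen, the six-membered aromatic ring of carbon only is gone and the read-out in this assay stays within the scatter, a 1.2-fold lower number from compound 3 to compound 4 (0.06 log units; within the scatter), so the large steps seen earlier cannot be tied to the loss of the phenyl alone. The same allyl keeps large steps to the other two groups, a 90-fold lower number from compound 2 to compound 4 (1.95 log units; beyond the scatter) and a 1200-fold lower number from compound 1 to compound 4 (3.06 log units; beyond the scatter), so across these four compounds the low numbers go with the two substituents made of carbon only, while the 1-methyl-1H-imidazol-2-yl and oxetan-3-yl compounds give the higher numbers. Nothing at hand explains why the phenyl and allyl compounds stand together or why the other two stand apart.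

On these data alone, whether the double bond of the allyl matters remains open, and a propyl group or a longer chain on the amide-type nitrogen would bear on that. Also open, as far as these compounds go, is whether the carbon-only pattern holds beyond four compounds, which a cyclohexyl or pyridin-2-yl group, or an allyl-length chain ending in an amine, would test.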